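From amino to fluoro on a shared core

The source may report more compounds than this note shows. Statements on the series, on what has been measured and on what is new or still open speak of the compounds shown alone.

Compound 1 `Nc1cccc(-c2cccc(NC(=O)C(Cl)Cl)c2)c1` gives 50000 nM
Compound 2 `O=C(Nc1cccc(-c2ccccc2C(F)(F)F)c1)C(Cl)Cl` gives 7500 nM

In a functional assay on A549 cells (Homo sapiens) for cytotoxicity, read by MTT assay, with a stated time of 68 h (a lower number here means a stronger inhibitor, a higher number a weaker inhibitor), compound 1 has the higher of the two numbers, which makes it the weaker inhibitor of the pair. Compound 2 sits lower, and the gap lies beyond the usual scatter. The next compound, compound 3 `O=C(Nc1cccc(-c2cccc(F)c2)c1)C(Cl)Cl`, keeps the core of compound 1 but carries fluoro in place of amino on an aromatic carbon. Among the measured compounds shown here, no two measured compounds differ in just one place, so nothing shows the effect of this swap directly. Compound 2, which also has no amino group, gives 7500 nM and offers the only hint. On that hint, the estimated change is a 5.0-fold lower number from compound 1 to compound 3 (0.70 log units; beyond the scatter) and would mean a stronger inhibitor, beyond the scatter. For compound 3 the expected value in this assay is 10000 nM (4000 nM to 30000 nM).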

Compound 3, half-maximal inhibitory concentration: 9530 nM
Compound 3: middle estimate off by 1.0-fold (0.02 log units), on the high side, within the range that was stated.
By their numbers in this assay, from the lowest: compounds 2 and 3 (each within the scatter of the next); then compound 1.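

Among the compounds shown here, this is the first direct reading of a single change on the shared core: in this assay, fluoro in place of amino on this aromatic carbon gives a 5.2-fold lower number from compound 1 to compound 3 (0.72 log units; beyond the scatter), a modest move toward a stronger inhibitor. The amino group counts as a hydrogen-bond donor and acceptor and fluoro as neither, so at this position cytotoxicity is not lost when both are gone. Nothing measured here bears on the reason for this step.

On these data alone, whether the gain comes from having fluoro or simply from losing amino stays open, since a single swap cannot separate the two. A hydrogen, a chlorine, a hydroxyl or a methoxy group on the same carbon would help to tell them apart.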